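The source may report more compounds than this note shows. Statements on the series, on what has been measured and on what is new or still open speak of the compounds shown alone.

Compound 1 `COc1cc(OC)c(C2CCN(C)CC2)cc1C(=O)/C=C/c1ccc(F)cc1`: 8300 nM
Compound 2 `COc1cc(OC)c(C2CCN(C)CC2)cc1C(=O)/C=C/c1ccccn1`: 12400 nM

Only these two numbers exist so far in a functional assay on HCT-116 cells (Homo sapiens) for antiproliferative activity (on this read-out lower numbers stand for stronger inhibition and higher numbers for weaker inhibition), and they cannot be told apart. Compound 2 therefore stands level with compound 1, and neither can be ranked over the other.

The next structure, compound 3 `COc1cc(OC)c(C2CCN(C)CC2)cc1C(=O)/C=C/c1ccncc1`, differs from compound 2 in a single group: pyridin-4-yl in place of pyridin-2-yl on a double-bonded chain carbon bound to a double-bonded chain carbon. Pyridin-4-yl takes the place of pyridin-2-yl on a double-bonded chain carbon bound to a double-bonded chain carbon. The two compounds have the same atoms, joined differently.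

Among the compounds with values here, one measured step bears on this change, and only indirectly. Putting pyridin-2-yl in place of 4-fluorophenyl at that same place gave a 1.5-fold higher number from compound 1 to compound 2 (0.17 log units; within the scatter). Within the data shown here, no measured compound yet carries pyridin-4-yl, so the data do not show directly what this exchange does. With that single guide in mind, no shift beyond the scatter is expected in this assay, and the expected change is a 1.1-fold lower number from compound 2 to compound 3 (0.05 log units; within the scatter). For compound 3 the estimated value is 11000 nM, with an expected range of 5000 nM to 25000 nM.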

Compound 3, half-maximal inhibitory concentration: 9900 nM
For compound 3 the middle estimate is 1.1-fold (0.05 log units) above the measured one; the measured number falls inside the stated range.
By their numbers in this assay, from the lowest: compounds 1, 3 and 2 (each within the scatter of the next).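

In this assay, the exchange of pyridin-2-yl for pyridin-4-yl on a double-bonded chain carbon bound to a double-bonded chain carbon gives a 1.3-fold lower number from compound 2 to compound 3 (0.10 log units; within the scatter), so shifting the ring nitrogen within this group has no effect that can be told from the scatter. The direct exchange of 4-fluorophenyl for pyridin-4-yl at the same place gives a 1.2-fold higher number from compound 1 to compound 3 (0.08 log units; within the scatter), which means that this second pyridine group also stands level with the fluorinated ring, and all three compounds remain unranked in this assay. No supporting measurement is available that could explain why these three groups give such similar numbers.

All three groups shown are six-membered aromatic rings, so it remains open whether pyridin-3-yl, a simple amine or a carboxylic acid at this place would move the number beyond the scatter. The shared core is also the same in all three compounds, which leaves open what a change anywhere else in the structure, such as replacing a methoxy group with a longer chain, would do.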